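Triazole substituent change on the shared core, compound 1 to compound 4

The compounds below may be only part of what the source reports. "The series", "measured", "known", "first", "only" and "open" are said of these compounds alone.

Measured so far:
- compound 1, `CCCCCc1ccc(-c2cn(C[C@H](O)[C@H]3OC(=O)C(OCc4ccccc4)=C3OCc3ccccc3)nn2)cc1`, gives 6220 nM in a functional assay on A549 cells (Homo sapiens) for antiproliferative activity, read by MTT assay, with a stated time of 72 h; a higher number here means a weaker inhibitor, a lower number a stronger inhibitor.
- compound 2, `CC(C)(C)OC(=O)N1CCN(C(=S)SCc2cn(C[C@H](O)[C@H]3OC(=O)C(OCc4ccccc4)=C3OCc3ccccc3)nn2)CC1`, gives only a limit of this assay, > 100000 nM.
- compound 3, `O=C1O/C(=C\Cn2cc(-c3cc(C(F)(F)F)cc(C(F)(F)F)c3)nn2)C(OCc2ccccc2)=C1OCc1ccccc1`, likewise gives only a limit of this assay, > 100000 nM.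

For the measured compounds named here, compound 1 is thus the only member of the set with a numerical result in this assay; the other two sit at the limit of > 100000 nM in this assay, at which 2 of the 3 values shown sit. Going by the values given here, nothing here connects compound 1 to compound 2 or compound 3 by a single change, so no measured step is available.

Compound 4, `O=C1O[C@H]([C@@H](O)Cn2cc(CCO)nn2)C(OCc2ccccc2)=C1OCc1ccccc1`, differs from compound 1 at one place: 2-hydroxyethyl in place of 4-pentylphenyl on an aromatic carbon. The 4-pentylphenyl of compound 1 is the only feature that separates it from the two compounds that reached no number, and removing it for a 2-hydroxyethyl is expected to weaken inhibition in this assay, a step of a 4.8-fold higher number from compound 1 to compound 4 (0.68 log units; beyond the scatter) expected to lie beyond the scatter. Compound 4 is therefore estimated at 30000 nM, within 8000 nM to 100000 nM, with a real chance that only a limit is reported.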

Compound 4, half-maximal inhibitory concentration: > 100000 nM
Compound 4: a limit, no number (the forecaster's own chance of this, stated with the estimate: 40%); at least 3.3-fold (0.52 log units) between middle value and limit.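

For the compounds shown here, this gives the first measured step at this position: 2-hydroxyethyl in place of 4-pentylphenyl on an aromatic carbon of the five-membered aromatic ring with 3 nitrogen produces an at least 16-fold higher number from compound 1 to compound 4 (1.20 log units; beyond the scatter). On these data alone, compound 4 gives > 100000 nM in this assay, which is a limit and not a number, so the true size of the step stays unknown. Of the two groups compared at this position, only 4-pentylphenyl gives a numerical result, and compound 1 remains the only compound with one: the limit of > 100000 nM in this assay, at which 3 of the 4 values shown sit.

This single pair does not separate the loss of the six-membered aromatic ring from the loss of the pentyl chain or the entry of the hydroxyl group. Open, as far as these compounds go, is whether an unsubstituted phenyl or a straight pentyl chain at this place would give a number in this assay.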